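The compounds below may be only part of what the source reports. "The series", "measured", "known", "first", "only" and "open" are said of these compounds alone.

In a functional assay on MDA-N cells (Homo sapiens) for antiproliferative activity (on this read-out lower numbers stand for stronger inhibition of growth and higher numbers for weaker inhibition of growth), compound 1 `Oc1cc(-c2ccc3ccccc3c2)nc2ncccc12` gives 1660 nM. Going by the values given here, only one other compound has a measured value so far: compound 2 `Cc1ccc2c(O)cc(-c3ccc4ccccc4c3)nc2n1` gives 1950 nM, which lies within the scatter of the first, so neither can be ranked above the other. Compound 3 `Cc1cnc2nc(-c3ccc4ccccc4c3)cc(O)c2c1` has not yet been measured. Its structure departs from the core of compound 1 in one place: methyl in place of hydrogen on an aromatic carbon. This is a methyl in place of hydrogen on an aromatic carbon, two atoms from the ring nitrogen. Among the compounds with values here, one measured step bears on this, the same kind of swap at a different aromatic carbon: a 1.2-fold higher number from compound 1 to compound 2 (0.07 log units; within the scatter). A single small step is thin evidence, but it gives no reason to expect a shift beyond the scatter in this assay. The expected change is therefore small: a 1.1-fold higher number from compound 1 to compound 3 (0.04 log units; within the scatter). Compound 3 is expected to give about 1800 nM, with an estimated range of 850 nM to 3800 nM.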

Compound 3, concentration for 50% growth inhibition: 132 nM
For compound 3 the middle estimate is 14-fold (1.13 log units) above the measured one; the measured number lies below the stated range.
By their numbers in this assay, from the lowest: compound 3; then compounds 1 and 2 (each within the scatter of the next).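

The same swap of hydrogen for methyl does not count equally at every aromatic carbon of the shared core. In this assay, the step at this carbon, two atoms from the ring nitrogen, is a 13-fold lower number from compound 1 to compound 3 (1.10 log units; beyond the scatter), whereas at the other carbon it is a 1.2-fold higher number from compound 1 to compound 2 (0.07 log units; within the scatter). So the position of this single added carbon decides whether growth inhibition becomes clearly stronger, and no measurement at hand accounts for that difference.

The compounds shown leave open whether the stronger inhibition is particular to methyl or would also appear with a longer chain such as ethyl, or with a different group such as an amine or a chlorine atom, at this carbon. They also leave open whether the step would hold on other cell types.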